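A few compounds are considered here, and "the series" means these few. Any claim that something is new, unique, unknown or untested is made for them only; others in the source may bear on it.

Measured in a functional assay on K562 cells (Homo sapiens) for antiproliferative activity, read by MTT assay, with a stated time of 72 h (a lower number here means a stronger inhibitor, a higher number a weaker inhibitor), so far:
- Compound 1 (`COc1cc(-c2ncnn2-c2cccc(N)c2)cc(OC)c1OC`): > 10000 nM as a limit of the assay
- Compound 2 (`COc1ccc(-c2ncnn2-c2cc(OC)c(OC)c(OC)c2)cc1`): 950 nM as a number
- Compound 3 (`COc1cc(-c2ncnn2-c2ccc(Cl)cc2)cc(OC)c1OC`): > 10000 nM as a limit of the assay

Compound 2 alone has a number. Beyond it the data offer only the limit of > 10000 nM in this assay, at which 2 of the 3 values shown sit, and nothing finer.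

The change from compound 2 to compound 4 (`COc1cc(-n2ncnc2-c2cccc(Cl)c2)cc(OC)c1OC`), 3-chlorophenyl in place of 4-methoxyphenyl on an aromatic carbon, counts as 3-chlorophenyl in place of 4-methoxyphenyl on an aromatic carbon and remains unmeasured. Among the compounds with values here, the one measured step (a step that the two limits leave unreadable from compound 1 to compound 3) has no readable size and sits on an aromatic nitrogen, so it sets no scale here. Compound 3 also carries a chlorophenyl and gives > 10000 nM as a limit. On that slim ground, weaker inhibition is expected in this assay with the estimated step (a 4.2-fold higher number from compound 2 to compound 4 (0.62 log units; beyond the scatter)) uncertain in size. For compound 4 the estimate is 4000 nM with an expected range (700 nM to 15000 nM).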

Compound 4, half-maximal inhibitory concentration: > 10000 nM
Compound 4: a limit, no number; the forecaster's own chance of this, stated with the estimate: 40%; at least 2.5-fold (0.39 log units) between middle value and limit.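

In this assay, the aromatic carbon of the five-membered ring now has a readable step, with 3-chlorophenyl in place of 4-methoxyphenyl giving an at least 10-fold higher number from compound 2 to compound 4 (1.02 log units; beyond the scatter). Compound 4 gives > 10000 nM, which is a limit of the assay and not a number. Compound 2 remains the only compound with a number, and the rest of the series offers only this ceiling: the limit of > 10000 nM in this assay, at which 3 of the 4 values shown sit.

The step swaps the methoxy group and the chlorine together, and does not separate the loss of one from the entry of the other. On these data alone, how a 4-hydroxyphenyl or a 4-ethoxyphenyl group on this carbon compares with 4-methoxyphenyl stays open.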